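The source may report more compounds than this note shows. Statements on the series, on what has been measured and on what is new or still open speak of the compounds shown alone.

Going by the values given here, the measure followed here is a physicochemical assay for lipophilicity, read by NMR (on this read-out lower numbers stand for lower lipophilicity and higher numbers for higher lipophilicity), and three compounds have a number so far. Compound 1 (`CC(F)(F)COc1ccc2[nH]ccc2c1`) gives 2.7 here, the highest of the three. Compound 2 (`CC[C@H](F)[C@H](C)O`) gives 0.68 and compound 3 (`OCCCC(F)C(F)F`) gives 0.52 as its number, both well under compound 1 and beyond the usual scatter. Among the compounds with values here, those two are built quite differently from compound 1, and no two measured compounds differ in one place only, so no measured step can guide the next one.

Compound 4 (`FCC(F)COc1ccc2[nH]ccc2c1`) keeps the core of compound 1 and alters one group, on a saturated chain carbon bound to an oxygen on an aromatic ring (1,2-difluoroethyl in place of 1,1-difluoroethyl on a saturated chain carbon bound to an oxygen on an aromatic ring). There, 1,2-difluoroethyl stands in place of 1,1-difluoroethyl, so the two compounds have the same atoms, joined differently. A change this small might seem unlikely to matter, yet moving a fluorine along a chain need not leave the number untouched. In this assay a modest drop is expected, probably just beyond the scatter, though this is a judgement from the structural change alone. The estimated change is a number 0.50 log units lower from compound 1 to compound 4 (beyond the scatter) in size. Compound 4 is expected to read 2.2 with a likely range from 1.85 to 2.55 when it is measured.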

Compound 4, partition coefficient: 2.3
The estimate for compound 4 lay 0.10 log units below the measured number; the range from low to high includes it.
By their numbers in this assay, from the lowest: compounds 3 and 2 (each within the scatter of the next); then compound 4; then compound 1.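

Going by these compounds alone, this is the first measured step, and it shows that in this assay the read-out at this position, on a saturated chain carbon bound to an oxygen on an aromatic ring, depends on how the fluorines are arranged and not only on which atoms are present: 1,2-difluoroethyl in place of 1,1-difluoroethyl gives a number 0.40 log units lower from compound 1 to compound 4 (beyond the scatter). The two groups have the same count of heavy atoms, 2 carbon and 2 fluorine, with no ring and no net charge, so this modest step separates two compounds that differ only in how the same atoms are joined. Nothing shown here gives a measured reason for the size of this step.

The compounds shown leave open whether the same exchange would give a step of similar size on a different core, as a single pair sets no pattern. They also leave open how a plain ethyl group, a trifluoromethyl group or a longer chain would read at this same place on the core of compound 1.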